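The compounds below may be only part of what the source reports. "The series", "measured", "known", "first", "only" and "open" are said of these compounds alone.

In a functional assay on Ishikawa cells (Homo sapiens) for antiproliferative activity, read by CCK-8 assay, with a stated time of 48 h (a higher number here means a weaker inhibitor, a lower number a stronger inhibitor), compound 3 `O=C(CCCNCCOc1ccc(Oc2c(-c3ccc(F)cc3)sc3cc(O)ccc23)cc1)N1CCC1` gives > 25000 nM, which is a limit of the assay and not a number. The change to compound 4 `O=C(/C=C/CNCCOc1ccc(Oc2c(-c3ccc(F)cc3)sc3cc(O)ccc23)cc1)N1CCC1` is 2-((azetidin-1-yl)carbonyl)ethenyl in place of 2-((azetidin-1-yl)carbonyl)ethyl on a saturated chain carbon bound to an amine nitrogen. Among the ethenyl amides, compound 1 `CNC(=O)/C=C/CNCCOc1ccc(Oc2c(-c3ccc(F)cc3)sc3cc(O)ccc23)cc1` gives 15500 nM and compound 2 `CN(C)C(=O)/C=C/CNCCOc1ccc(Oc2c(-c3ccc(F)cc3)sc3cc(O)ccc23)cc1` gives 11900 nM. Changing the amide there gives a 1.3-fold lower number from compound 1 to compound 2 (0.11 log units; within the scatter). The steps from the ethenyl amides to the saturated chain are an at least 1.6-fold higher number from compound 1 to compound 3 (0.20 log units; that floor lies within the scatter) and an at least 2.1-fold higher number from compound 2 to compound 3 (0.32 log units; beyond the scatter), and both also change the amide group. A lower number is therefore expected for compound 4 in this assay, with an estimated step of an at least 1.9-fold lower number from compound 3 to compound 4 (0.28 log units; that floor lies within the scatter). Compound 4 is estimated at 13000 nM, with an expected range of 7000 nM to 25000 nM.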

Compound 4, half-maximal inhibitory concentration: 6560 nM
Compound 4: middle estimate off by 2.0-fold (0.30 log units), on the high side, and the stated range ends above it.
By their numbers in this assay, from the lowest: compounds 4, 2 and 1 (each within the scatter of the next, the first and the last beyond it). At a limit, above all of these: compound 3.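

Going by these compounds alone, with the azetidin-1-yl amide held fixed, the 2-((azetidin-1-yl)carbonyl)ethenyl group in place of 2-((azetidin-1-yl)carbonyl)ethyl gives an at least 3.8-fold lower number from compound 3 to compound 4 (0.58 log units; beyond the scatter), the first step at this position where the amide does not change as well. Compound 3 stands at a limit, not a number: the limit of > 25000 nM in this assay, at which 1 of the 4 values shown sits. Among the ethenyl amides, azetidin-1-yl gives a 2.4-fold lower number from compound 1 to compound 4 (0.37 log units; beyond the scatter) against methylamino, but only a 1.8-fold lower number from compound 2 to compound 4 (0.26 log units; within the scatter) against dimethylamino.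

On these data alone, the full size of the step from the saturated chain remains open, as does whether it holds for a saturated dimethylamide. Also open, as far as these compounds go, is how a piperidin-1-yl amide, or a carboxylic acid in place of the amide, would compare.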